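N-substituent variation on a shared core: cytotoxicity notes

This account rests on a few compounds, and the source may have more. Where it says the series, first, only, none or still open, it means among the compounds named here.

Measured in a functional assay on MCF7 cells (Homo sapiens) for cytotoxicity, read by sulforhodamine B assay, with a stated time of 48 h; a lower number here means a stronger inhibitor, a higher number a weaker inhibitor:
- compound 1, `C#CCn1c(-c2ccc(Cl)cc2)cc(-c2ccc(Cl)cc2)c(C#N)c1=O`: 16.7 ug/mL
- compound 2, `N#Cc1c(-c2ccc(Cl)cc2)cc(-c2ccc(Cl)cc2)n([C@@H]2O[C@H](CO)[C@@H](O)[C@H]2O)c1=O`: 5.7 ug/mL
- compound 3, `CC(=O)OC[C@H]1O[C@@H](n2c(-c3ccc(Cl)cc3)cc(-c3ccc(Cl)cc3)c(C#N)c2=O)[C@H](OC(C)=O)[C@@H](OC(C)=O)[C@@H]1OC(C)=O`: 6.3 ug/mL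
- compound 4, `N#Cc1c(-c2ccc(Cl)cc2)cc(-c2ccc(Cl)cc2)n(CC2CO2)c1=O`: not yet measured

Compound 2 stands at the low end of the three numbers in this assay. Compound 3 sits within the scatter of it, so the two cannot be ordered. Within the data shown here, the one step that clears the scatter is a 2.9-fold lower number from compound 1 to compound 2 (0.47 log units; beyond the scatter), a modest one, which replaced propargyl on the aromatic nitrogen with the 3,4-dihydroxy-5-(hydroxymethyl)oxolan-2-yl group.

Compound 4 differs from compound 2 by (oxiran-2-yl)methyl in place of 3,4-dihydroxy-5-(hydroxymethyl)oxolan-2-yl on an aromatic nitrogen. This removes the group whose entry gave that only clear step and puts in its place a small substituent of four heavy atoms, which is closer in size to the propargyl of compound 1 than to the oxolane of compound 2. The step from compound 1 to compound 2 therefore bears on it, run in reverse. A modest move toward a higher number is expected in this assay, of about the size of a 2.1-fold higher number from compound 2 to compound 4 (0.32 log units; beyond the scatter), although a result within the scatter cannot be excluded on three compounds. The estimate for compound 4 is 12 ug/mL, with a range of 6 ug/mL to 25 ug/mL.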

Compound 4, half-maximal inhibitory concentration: 5 ug/mL
Estimate against measurement, compound 4: 2.4-fold (0.38 log units) above; measured number outside the range, below it.
By their numbers in this assay, from the lowest: compounds 4, 2 and 3 (each within the scatter of the next); then compound 1.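

In this assay, the low end of the series does not depend on the 3,4-dihydroxy-5-(hydroxymethyl)oxolan-2-yl group: a 1.1-fold lower number from compound 2 to compound 4 (0.06 log units; within the scatter) leaves the two compounds unordered, although (oxiran-2-yl)methyl brings 4 heavy atoms in place of 9 and 0 hydrogen-bond donors in place of 3. Substituent size alone therefore does not account for the higher number of compound 1, since a 3.3-fold lower number from compound 1 to compound 4 (0.52 log units; beyond the scatter) separates two small substituents that differ only in oxiran-2-yl in place of ethynyl on the saturated chain carbon bound to the aromatic nitrogen. No measurement here gives a basis for explaining either step.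

The compounds shown leave open whether the three-membered ring itself is needed or whether ethynyl is the exception. A plain propyl chain or a chain ending in an amine on this nitrogen would help to separate these readings in this assay.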